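A Bromine Atom Enters the Reduced Core

A few compounds are considered here, and "the series" means these few. Any claim that something is new, unique, unknown or untested is made for them only; others in the source may bear on it.

Three measured compounds frame this step. Compound 1 `O=C1NC[C@@H](c2c[nH]c3cc(Br)ccc23)N=C1c1c[nH]c2ccccc12` gives 7.6 ug/mL in an ADME assay on SK-MEL-2 cells (Homo sapiens) for cytotoxicity; on this read-out lower numbers stand for an effect already at smaller amounts and higher numbers for an effect only at larger amounts of compound. Compound 3 `O=C(C1=NC(c2c[nH]c3cc(Br)ccc23)CN1)c1c[nH]c2cc(Br)ccc12` gives 4.82 ug/mL in this assay. Compound 2 `O=C1NC[C@@H](c2c[nH]c3ccccc23)N[C@H]1c1c[nH]c2ccccc12` is the starting point of the step, and in this assay compound 2 reaches only a limit, > 10 ug/mL. Compound 2 therefore stands at the limit of > 10 ug/mL in this assay, at which 1 of the 3 values shown sits. Compound 4 `O=C1NC[C@@H](c2c[nH]c3cc(Br)ccc23)N[C@H]1c1c[nH]c2ccccc12` differs from compound 2 in one place: bromo in place of hydrogen on an aromatic carbon. Within the data shown here, no measured pair shows this exact change, so the size of the step is open. The two compounds that carry bromine, compound 1 with 7.6 ug/mL and compound 3 with 4.82 ug/mL, both give numbers rather than limits, which suggests that compound 4 may also give a number. The step from compound 2 to compound 4 is expected to be an at least 1.2-fold lower number from compound 2 to compound 4 (0.09 log units; that floor lies within the scatter), toward an effect at smaller amounts, though it could stay within the scatter or again end at a limit. Compound 4 is estimated at 8 ug/mL, with a range from 4 ug/mL to 16 ug/mL.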

Compound 4, concentration for half-maximal effect: 7.1 ug/mL
Estimate against measurement, compound 4: 1.1-fold (0.05 log units) above; measured number inside the range.
By their numbers in this assay, from the lowest: compounds 3, 4 and 1 (each within the scatter of the next). At a limit, above all of these: compound 2.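

Compound 4 gives a measured number in this assay, so on the core it shares with compound 2, bromo in place of hydrogen on an aromatic carbon brings the read-out from a limit to a value. The change amounts to an at least 1.4-fold lower number from compound 2 to compound 4 (0.14 log units; that floor lies within the scatter). Because compound 2 has only a limit, that figure is a floor, so the real step may be larger, but the data cannot show by how much: the limit of > 10 ug/mL in this assay, at which 1 of the 4 values shown sits.

The compounds shown leave open whether the number depends on bromine itself, as no other group, such as chloro, methoxy or an amine, appears at this position on this core. From the compounds shown here alone, it also remains open whether bromo at a different aromatic carbon of this core would give a similar number.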